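This account rests on a few compounds, and the source may have more. Where it says the series, first, only, none or still open, it means among the compounds named here.

Series notes. Compound 1 `c1ccc(-c2ccncc2)c(OCC2=NCCN2)c1` and compound 2 `c1ccc(-c2cc[nH]n2)c(OCC2=NCCN2)c1` share one core and differ only in the aryl group on an aromatic carbon. In a functional assay for activation of Alpha-1A adrenergic receptor (Homo sapiens), read by calcium flux (a lower number here means that less compound is needed, a higher number that more compound is needed for the effect), compound 1 returns only a limit, < 100000 nM, not a number. In this assay, among the compounds with values here, compound 2 gives 5.01 nM, the sole number obtained so far in the set. The step that the limit leaves unreadable from compound 1 to compound 2 therefore cannot be sized, since the limit of < 100000 nM in this assay, at which 1 of the 2 values shown sits, caps what the first compound shows. Compound 3 `c1ccc(-c2ncc[nH]2)c(OCC2=NCCN2)c1` is the next member: the change is 1H-imidazol-2-yl in place of 1H-pyrazol-3-yl on an aromatic carbon, the two compounds having the same atoms joined differently. Within the data shown here, no measured step bears directly on this rearrangement, the only one recorded being unreadable, so the expectation rests on compound 2 alone. For compound 3 the estimate is a step of a 4.0-fold higher number from compound 2 to compound 3 (0.60 log units; beyond the scatter) in this assay, around 20 nM with a range of 3 nM to 150 nM.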

Compound 3, half-maximal effective concentration: 100 nM
The estimate for compound 3 lay 5.0-fold (0.70 log units) below the measured number; the range from low to high includes it.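

Exchanging 1H-pyrazol-3-yl for 1H-imidazol-2-yl gives a 20-fold higher number from compound 2 to compound 3 (1.30 log units; beyond the scatter) in this assay, so this position on the aromatic ring responds to a rearrangement of atoms within the five-membered ring. The two groups have the same counts of heavy atoms, hydrogen-bond donors and hydrogen-bond acceptors and carry no net charge, so for this pair those counts alone do not set the number. The steps from compound 1 cannot be read, and its value is a limit, not a number: the limit of < 100000 nM in this assay, at which 1 of the 3 values shown sits.

Still open, on these data alone, is how a 1,2,4-triazole, a phenyl or a methyl-bearing pyrazole would stand at this position. Also open, as far as these compounds go, is whether the gap between 1H-pyrazol-3-yl and 1H-imidazol-2-yl would persist with a different substituent elsewhere on the shared core.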